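Restoring methylsulfanyl opposite the ring nitrogen

This account rests on a few compounds, and the source may have more. Where it says the series, first, only, none or still open, it means among the compounds named here.

Three ureas share one core and were tested in an assay for inhibition of acyl-CoA:cholesterol acyltransferase (Oryctolagus cuniculus), using microsomes; a lower number here means a stronger inhibitor, a higher number a weaker inhibitor. Compound 1 `COc1nc(C)cc(SC)c1NC(=O)N(Cc1ccc(Oc2ccc(F)cc2)cc1)C1CCCCCC1` gives 29 nM. For the measured compounds named here, compound 2 `CSc1cc(C)nc(Cl)c1NC(=O)N(Cc1ccc(Oc2ccc(F)cc2)cc1)C1CCCCCC1` gives 46 nM, and the only single-point step, a 1.6-fold higher number from compound 1 to compound 2 (0.20 log units; within the scatter), stays within the scatter. Compound 3 `Cc1cc(S(C)(=O)=O)c(NC(=O)N(Cc2ccc(Oc3ccc(F)cc3)cc2)C2CCCCCC2)c(S(C)(=O)=O)n1` gives 45 nM, which lies second highest of the three numbers, within the scatter of both compound 2 and compound 1. Compound 4 `CSc1cc(C)nc(S(C)(=O)=O)c1NC(=O)N(Cc1ccc(Oc2ccc(F)cc2)cc1)C1CCCCCC1` differs from compound 3 by methylsulfanyl in place of methylsulfonyl on an aromatic carbon. Going by the values given here, no measured step covers this exchange; compound 1 and compound 2 merely show that the methylsulfanyl-bearing core sits in the same band as compound 3. The step of a 1.3-fold lower number from compound 3 to compound 4 (0.11 log units; within the scatter) is therefore expected to stay within the scatter. Compound 4 is estimated at 35 nM, with a range from 15 nM to 90 nM.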

Compound 4, half-maximal inhibitory concentration: 78 nM
The estimate for compound 4 lay 2.2-fold (0.35 log units) below the measured number, within the range that was stated.
By their numbers in this assay, from the lowest: compounds 1, 3, 2 and 4 (each within the scatter of the next, the first and the last beyond it).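

At the aromatic carbon opposite the ring nitrogen, methylsulfanyl in place of methylsulfonyl gives a 1.7-fold higher number from compound 3 to compound 4 (0.24 log units; within the scatter) in this assay, so this exchange is not separated from the scatter. Among the compounds carrying methylsulfanyl there, methylsulfonyl in place of chloro gives a 1.7-fold higher number from compound 2 to compound 4 (0.23 log units; within the scatter), while methylsulfonyl in place of methoxy gives a 2.7-fold higher number from compound 1 to compound 4 (0.43 log units; beyond the scatter), the only step in the series beyond the scatter. No available evidence accounts for these steps. The compounds shown leave open whether an amine or a longer chain such as ethylsulfanyl at that carbon would stay in the same band.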